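The compounds below may be only part of what the source reports. "The series", "measured", "known", "first", "only" and "open" are said of these compounds alone.

Of the compounds shown here, two have been tested so far in a functional assay on the whole organism for inhibition, with Rattus norvegicus as the target, in the maximal electroshock model, at a dose of 25 mg/kg by the intraperitoneal route; on this read-out lower numbers stand for less inhibition and higher numbers for more inhibition at the one dose given (going by the name of the read-out). Compound 1, with the structure `CN(C)c1ncnc2c1ncn2C`, carries a methyl group on the shared core, and in this assay compound 1 gives 33%. Compound 2, drawn as `C[C@H](c1ccccc1)n1cnc2c(N(C)C)ncnc21`, carries a 1-phenylethyl group on the same core in place of that methyl, and in this assay compound 2 gives 33%. Compound 2 therefore stands level with compound 1 at the digits reported, the two values lying within the usual scatter of each other, so nothing can be said of any order between them.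

Compound 3, with the structure `C[C@@H](c1ccccc1)n1cnc2c(N(C)C)ncnc21`, is the mirror image of compound 2 at one centre: the two compounds have the same atoms and bonds and differ only in configuration as drawn: 1 of 1 stereo elements differ; a stereocentre at a saturated chain carbon is drawn R in compound 2 and S in compound 3. Within the data shown here, no measured pair in this set shows what such a change in configuration does on this read-out, so the expected step from compound 2 to compound 3 is taken as a number 3 percentage points lower from compound 2 to compound 3 (within the scatter), essentially none beyond the scatter, though a larger move in either direction cannot be ruled out. On that basis compound 3 is estimated to give 30% in this assay, with a likely range from 8% to 58%.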

Compound 3, a percentage reported as inhibition, in the whole organism at one dose (the size of the read-out at that dose, not a potency): 33%
The estimate for compound 3 lay 3 percentage points below the measured number, within the range that was stated.
By their numbers in this assay, from the lowest: compounds 1, 2 and 3 (each within the scatter of the next).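

Compounds 1 and 2 could only compare a methyl group with a 1-phenylethyl group on the shared core, so they said nothing about the three-dimensional arrangement at that group's stereocentre. In this assay, changing that stereocentre from R to S gives no change at the digits printed from compound 2 to compound 3 (within the scatter), so at this one dose the read-out does not tell the two mirror images apart. This makes the pair an unusually direct test of configuration, since no group enters or leaves and the comparison rests on a single structural fact: the fact that compounds 2 and 3 differ only in the configuration as drawn

As far as these compounds go, because the read-out is a size of effect at a single dose and not a potency, it remains open whether the two mirror images would also stay level at other doses. The compounds shown also leave open what a longer chain, such as a 3-phenylpropyl group, or a carboxylic acid would do in place of the 1-phenylethyl group, and what a primary amine would do in place of the dimethylamino group.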